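The source may report more compounds than this note shows. Statements on the series, on what has been measured and on what is new or still open speak of the compounds shown alone.

In a functional assay on MT2 cells (Homo sapiens) for cytotoxicity, read by MTT assay (on this read-out higher numbers stand for lower toxicity in this test and lower numbers for higher toxicity in this test), compound 3 `CC(C)=CCOc1cc(Nc2nccc(C)n2)ccc1Cl` does not return a number but a limit of the assay, namely < 200 nM, as explained by the limit of < 200 nM in this assay, at which 1 of the 3 values shown sits. Among the compounds measured so far it sits at the toxic end of this assay. Compound 1 `CC(C)=CCOc1cc(Nc2nccs2)ccc1Cl` gives 26000 nM. Compound 2 `CC(C)=CCOc1cccc(Nc2ncccn2)c1` also gives only a limit, > 100000 nM, which is the other limit of this assay, (the limit of > 100000 nM in this assay, at which 1 of the 3 values shown sits). For the measured compounds named here, the one measured step, an at least 130-fold lower number from compound 1 to compound 3 (2.11 log units; beyond the scatter), shows that swapping the ring on the nitrogen of the shared core can move the value far beyond the scatter.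

Compound 4 `CC(C)=CCOc1cc(Nc2nccc(CO)n2)ccc1Cl` differs from compound 3 by hydroxy in place of hydrogen on a saturated chain carbon bound to an aromatic carbon. Going by the values given here, no measured step touches this change, and the only known step concerns a different part of the molecule, so it offers no direct guide. With compound 3 stuck at a limit, the expected step of an at least 2.5-fold higher number from compound 3 to compound 4 (0.39 log units; beyond the scatter) is uncertain and may well stay within the scatter. Compound 4 is therefore estimated at 500 nM, within a range of 100 nM to 5000 nM, with a fair chance that only a limit is reported again.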

Compound 4, half-maximal cytotoxic concentration: 220 nM
The estimate for compound 4 lay 2.3-fold (0.36 log units) above the measured number; low and high end bracket the measured number.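

Hydroxy in place of hydrogen on a saturated chain carbon bound to an aromatic carbon is the first change shown at this place, and in this assay it gives an at least 1.1-fold higher number from compound 3 to compound 4 (0.04 log units; that floor lies within the scatter). That floor does not establish any effect of the change, and the true step could be larger, because compound 3 rests on a limit rather than a number: the limit of < 200 nM in this assay, at which 1 of the 4 values shown sits. Compound 4 does give a true number, 220 nM, so further changes at this place can be compared against it in a way that compound 3 does not allow.

The compounds shown leave open what an amine, a carboxylic acid or a longer chain carrying the hydroxy would give at this place. Nor do they show what a plain hydrogen in place of the whole methyl would give on the core of compound 3.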